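Swapping a dichlorophenyl for a chlorophenyl on a piperazine

The source may hold more compounds than are shown below. What is called first, only, known or untested is meant among the compounds shown, and "the series" means these compounds.

Compound 1 `O=C1c2ccccc2S(=O)(=O)N1CCCCCCN1CCN(c2cccc(Cl)c2Cl)CC1` is tested in an assay on HEK293 cells for displacement of a labelled ligand from 5-hydroxytryptamine receptor 7 (Homo sapiens) (a lower number here means a stronger inhibitor, a higher number a weaker inhibitor), where compound 1 gives 487 nM. Among the three measured compounds this is the second highest number: compound 2 `COc1ccccc1N1CCN(CCCCCN2C(=O)c3ccccc3S2(=O)=O)CC1` gives 125 nM, and compound 3 `O=C1c2ccccc2S(=O)(=O)N1CCCCCN1CCN(c2ncccn2)CC1` gives 2670 nM. For the measured compounds named here, the one measured step, a 21-fold higher number from compound 2 to compound 3 (1.33 log units; beyond the scatter), concerns a different ring on the same nitrogen and does not bear directly on the change at hand. Compound 4 `O=C1c2ccccc2S(=O)(=O)N1CCCCCCN1CCN(c2ccc(Cl)cc2)CC1` differs from compound 1 by 4-chlorophenyl in place of 2,3-dichlorophenyl on an amine nitrogen in a ring. Going by the values given here, no measured pair shows this kind of change, so the direction is uncertain. The expected step of a 1.0-fold higher number from compound 1 to compound 4 (0.01 log units; within the scatter) is small, within the scatter. Compound 4 is therefore estimated at 500 nM, with a range from 150 nM to 1700 nM.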

Compound 4, inhibition constant: 487 nM
The estimate for compound 4 lay 1.0-fold (0.01 log units) above the measured number, and the stated range covers the measured number.
By their numbers in this assay, from the lowest: compound 2; then compounds 1 and 4 (each within the scatter of the next); then compound 3.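

In this assay there is no change at the digits printed from compound 1 to compound 4 (within the scatter), so at this amine nitrogen 2,3-dichlorophenyl and 4-chlorophenyl cannot be told apart. With the rest of the core of compound 1 held fixed, the number of chlorines and where they sit on this ring make no visible difference here. Nothing available explains why the two groups match.

Still open, from the compounds shown here alone, is whether a plain phenyl with no chlorine would also match. A trifluoromethyl or methoxy group in place of the chlorine on the same ring is equally unsettled.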